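The source may report more compounds than this note shows. Statements on the series, on what has been measured and on what is new or still open speak of the compounds shown alone.

The study concerns dithiocarbamate esters built on a shared chromone-type core and tested in a functional assay on HEp-2 cells (Homo sapiens) for antiproliferative activity, read by MTT assay, with a stated time of 72 h; on this read-out lower numbers stand for stronger inhibition and higher numbers for weaker inhibition. Compound 1 has the structure `O=c1c(SC(=S)N2CCCCC2)coc2ccccc12` and in this assay compound 1 gives 5800 nM. Compound 2, the starting point of the step traced here, has the structure `CCOC(=O)c1cc(=O)c2cc(CSC(=S)N3CCCC3)ccc2o1` and in this assay compound 2 gives 8900 nM. Among the two numbers recorded, the value of compound 2 and that of compound 1 lie within the usual scatter of each other, so no order between them can be read. Compound 3 has the structure `CN(C(=S)SCc1coc2ccccc2c1=O)c1ccccc1` and in this assay compound 3 reaches only a limit of the assay, > 25000 nM. That limit is noted as the limit of > 25000 nM in this assay, at which 1 of the 3 values shown sits.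

The unmeasured compound 4 has the structure `CCOC(=O)c1cc(=O)c2cc(CSC(=S)N3CCOCC3)ccc2o1`. It differs from compound 2 in one place: morpholin-4-yl in place of pyrrolidin-1-yl on a thiocarbonyl carbon. Within the data shown here, no measured pair in the set shows what such an exchange does on this core, so the expected step from compound 2 to compound 4, a 1.1-fold higher number from compound 2 to compound 4 (0.05 log units; within the scatter), is taken as none beyond the scatter, with the direction left open. On that basis compound 4 is expected to give about 10000 nM in this assay, with a plausible range from 4000 nM to 25000 nM.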

Compound 4, half-maximal inhibitory concentration: > 25000 nM
Compound 4: no number, only a limit (the forecaster's own chance of this, stated with the estimate: 25%); at least 2.5-fold (0.39 log units) between middle value and limit.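

Among these compounds, on the shared core of compound 2, the exchange of pyrrolidin-1-yl for morpholin-4-yl on a thiocarbonyl carbon gives the first reading of what this position does, and in this assay it is not neutral: the change brings an at least 2.8-fold higher number from compound 2 to compound 4 (0.44 log units; beyond the scatter). The entering ring carries one more heavy atom, an oxygen, and one hydrogen-bond acceptor, but these counts describe the change and do not explain the loss of inhibition. Compound 4 gives > 25000 nM, which is a limit of the assay and not a number, so the step fixes only the smallest size the change can have and its full size stays unknown: the limit of > 25000 nM in this assay, at which 2 of the 4 values shown sit.

The compounds shown leave open whether the ring oxygen itself drives this step, which thiomorpholin-4-yl or piperazin-1-yl on the same thiocarbonyl carbon could help to separate from the change in ring size. They also leave open whether the same exchange acts alike on the core of compound 1, and whether a carboxylic acid in place of the ethyl ester would alter the picture.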